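This account rests on a few compounds, and the source may have more. Where it says the series, first, only, none or still open, it means among the compounds named here.

Measured compounds:
- compound 1, `CCCCCCCCCCc1ccc(-c2noc(C3CNC3)n2)cc1`, 65% in an assay on HeLa cells for inhibition of sphingosine-1-phosphate transporter SPNS2 (Mus musculus), read by LC-MS, tested at 2 uM; a higher number here means more inhibition at the concentration tested (going by the name of the read-out), a lower number less inhibition
- compound 2, `CCCCCCCCCCc1ccc(-c2noc(CCCCN)n2)cc1`, 55% in this assay
- compound 3, `CCCCCCCCCCc1ccc(-c2noc(-c3cccc(CN)c3)n2)cc1`, 2% in this assay

Compound 3 stands lowest of the three numbers in this assay: its nearest neighbour is compound 2, a number 53 percentage points lower from compound 2 to compound 3 (beyond the scatter), and the furthest is compound 1, a number 63 percentage points lower from compound 1 to compound 3 (beyond the scatter). Compounds 1 and 2 sit within the scatter of each other, a number 10 percentage points lower from compound 1 to compound 2 (within the scatter), so the only clear movement among the measured compounds is the drop to the 3-(aminomethyl)phenyl group of compound 3.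

Compound 4, `CCCCCCCCCCc1ccc(-c2noc(CC(O)CN3CCCCC3)n2)cc1`, is not yet measured in this assay. It differs from compound 3 as follows: 2-hydroxy-3-(piperidin-1-yl)propyl in place of 3-(aminomethyl)phenyl on an aromatic carbon. The group that enters is a non-aromatic chain carrying a piperidin-1-yl nitrogen and a hydroxy group, and so it resembles the chain-type substituents of compound 1 and compound 2 more than the aromatic group of compound 3. Going by the values given here, the steps that bear on this change are the two large drops onto compound 3, a number 63 percentage points lower from compound 1 to compound 3 (beyond the scatter) and a number 53 percentage points lower from compound 2 to compound 3 (beyond the scatter). Reversing from the aromatic group to a chain is therefore expected to give a large step upward, a number 48 percentage points higher from compound 3 to compound 4 (beyond the scatter), although no measured compound carries a hydroxy group or a piperidine, so the exact level is uncertain. For compound 4 in this assay the estimate is 50%, with a range from 25% to 75%.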

Compound 4, a percentage reported as inhibition, at one concentration (the size of the read-out at that concentration, not a potency): 2%
Compound 4: middle estimate off by 48 percentage points, on the high side; the measured number lies below the stated range.
By their numbers in this assay, from the lowest: compounds 3 and 4 (each within the scatter of the next); then compounds 2 and 1 (each within the scatter of the next).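

Working notes on the group on the aromatic carbon next to the ring nitrogen and the ring oxygen: in this assay, a non-aromatic chain here does not by itself keep the level of the earlier chain-type compounds, with a number 53 percentage points lower from compound 2 to compound 4 (beyond the scatter) and a number 63 percentage points lower from compound 1 to compound 4 (beyond the scatter) on the same scale. Replacing the 3-(aminomethyl)phenyl group with 2-hydroxy-3-(piperidin-1-yl)propyl gives no change at the digits printed from compound 3 to compound 4 (within the scatter), so a low number at this position is not confined to an aromatic group, and the low pair holds two different nitrogen groups, a primary amine in compound 3 and a piperidine in compound 4. No measurement at hand accounts for the low number of compound 4.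

Open, from the compounds shown here alone, is whether the hydroxy group, the piperidine or both separate compound 4 from compound 2, which a 3-(piperidin-1-yl)propyl chain and a 3-amino-2-hydroxypropyl chain would help to resolve. Every compound shown carries an amine nitrogen in this group, so the outcome with a carboxylic acid or a plain alkyl chain here also remains open.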